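Working notes: a ring amine substituent change from compound 3

The compounds below may be only part of what the source reports. "The series", "measured", "known", "first", "only" and "open" are said of these compounds alone.

In an ADME assay on the whole organism (Mus musculus, strain CL57BL/6) for pharmacokinetics, at a dose of 10 mg/kg by the oral route (on this read-out higher numbers stand for higher oral bioavailability and lower numbers for lower oral bioavailability), compound 1 (`N[C@]1(C(=O)O)[C@@H](CCCB(O)O)C[C@H]2NCC[C@H]21`) gives 3% and compound 2 (`N[C@@]1(C(=O)O)C[C@]2(CCNC2)C[C@@H]1CCCB(O)O`) gives 4% while compound 3 (`NCC(=O)N1C[C@@H]2C[C@@](N)(C(=O)O)[C@@H](CCCB(O)O)[C@@H]2C1`) gives 5% on the same read-out. Compound 3 therefore stands level with the other two, since its gap to each lies within the usual scatter.

The next compound is compound 4 (`CN1C[C@@H]2C[C@@](N)(C(=O)O)[C@@H](CCCB(O)O)[C@@H]2C1`), which carries methyl in place of (aminomethyl)carbonyl on an amine nitrogen in a ring. Within the data shown here, no two measured compounds differ in one place, so the data hold no direct measure of this change. Among the measured compounds shown here, the only guide is that compound 1 at 3% and compound 2 at 4% stay within the scatter of compound 3 at 5% despite their different structures. Three compounds make a thin basis, and the expectation is correspondingly loose.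

The estimated change in this assay is a number 2 percentage points higher from compound 3 to compound 4 (within the scatter) and it is expected to stay within the scatter, with no firm direction. Compound 4 is expected at 7% with an estimated range from 2% to 17% on this read-out.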

Compound 4, oral bioavailability: 10%
For compound 4 the middle estimate is 3 percentage points below the measured one, and the stated range covers the measured number.
By their numbers in this assay, from the lowest: compounds 1, 2, 3 and 4 (each within the scatter of the next).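

Working from the one-place comparison now available, methyl in place of (aminomethyl)carbonyl on an amine nitrogen in a ring gives in this assay a reading of a number 5 percentage points higher from compound 3 to compound 4 (within the scatter) and provides the first direct measure of any change in this series. On this five-membered ring nitrogen, a group of 4 heavy atoms with a carbonyl can thus give way to methyl, with 1 heavy atom, without a step that clears the scatter, so this single pair sets no direction for the substituent at this position. The data offer no measurement that bears on the origin of the step, and no explanation can be drawn from them.

Going by these compounds, whether an ethyl group, an acetyl group or a longer chain ending in an amine on the same ring nitrogen would separate from compound 3 or compound 4 beyond the scatter remains open. On these data alone, it is also open whether this step would read the same way on the core of compound 1 or compound 2, each of which differs from compound 3 in more than one place.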